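Working notes on chain length at the ring carbon

This account rests on a few compounds, and the source may have more. Where it says the series, first, only, none or still open, it means among the compounds named here.

The series shares the core of compound 1 `O=C1O[C@H]([C@@H](O)Cn2cc(CCO)nn2)C(OCc2ccccc2)=C1OCc1ccccc1`, which in a functional assay on HCT-116 cells (Homo sapiens) for antiproliferative activity, read by MTT assay, with a stated time of 72 h (a higher number here means a weaker inhibitor, a lower number a stronger inhibitor), gives 72700 nM. Compound 2 `Cc1ccc(-c2cn(C[C@H](O)[C@H]3OC(=O)C(OCc4ccccc4)=C3OCc3ccccc3)nn2)cc1` reaches only a limit in this assay, > 100000 nM, as in the limit of > 100000 nM in this assay, at which 1 of the 3 values shown sits. Compound 3 `CCCCCc1ccc(-c2cn(C[C@H](O)[C@H]3OC(=O)C(OCc4ccccc4)=C3OCc3ccccc3)nn2)cc1` gives 13800 nM, the lowest of the two numbers, with compound 1 nearest through the step of a 5.3-fold lower number from compound 1 to compound 3 (0.72 log units; beyond the scatter). Compound 4 `CCCCCCCCCCc1cn(C[C@H](O)[C@H]2OC(=O)C(OCc3ccccc3)=C2OCc2ccccc2)nn1` carries decyl in place of 4-pentylphenyl on an aromatic carbon. The step of an at least 7.2-fold lower number from compound 2 to compound 3 (0.86 log units; beyond the scatter) bears most directly, as it also adds saturated chain carbons; the step of a 5.3-fold lower number from compound 1 to compound 3 (0.72 log units; beyond the scatter) bears on it too. A further lowering is expected, though with the ring gone its size is uncertain, so the estimated step is a 1.7-fold lower number from compound 3 to compound 4 (0.24 log units; within the scatter). Compound 4 is expected to give 8000 nM, within 2500 nM to 30000 nM.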

Compound 4, half-maximal inhibitory concentration: 28800 nM
Compound 4: the middle estimate sits 3.6-fold (0.56 log units) below what was measured; the range from low to high includes it.
By their numbers in this assay, from the lowest: compound 3; then compound 4; then compound 1. At a limit, above all of these: compound 2.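

On this aromatic carbon, decyl gives a lower number than 2-hydroxyethyl (a 2.5-fold lower number from compound 1 to compound 4 (0.40 log units; beyond the scatter)) and than 4-methylphenyl (an at least 3.4-fold lower number from compound 2 to compound 4 (0.54 log units; beyond the scatter)), so a six-membered aromatic ring is not required there for a readable value in this assay. The second of these steps is only a floor, as compound 2 stands at a limit: the limit of > 100000 nM in this assay, at which 1 of the 4 values shown sits.

Decyl still does not match 4-pentylphenyl (a 2.1-fold higher number from compound 3 to compound 4 (0.32 log units; beyond the scatter)), so the count of chain carbons alone does not set the order of these compounds.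

Open, as far as these compounds go, is whether a longer chain such as dodecyl would lower the number further. Also open, from the compounds shown here alone, is how a decyl chain ending in an amine would compare.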